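Astrocyte Cytotoxicity: Swapping the Aryl Group on the Urea

A few compounds are considered here, and "the series" means these few. Any claim that something is new, unique, unknown or untested is made for them only; others in the source may bear on it.

Of the compounds shown here, three sharing one core have been tested in an ADME assay on cells (Astrocyte, Homo sapiens) for cytotoxicity, read by WST assay, with a stated time of 72 h; on this read-out lower numbers stand for stronger inhibition and higher numbers for weaker inhibition. Compound 2 `O=C(Nc1ccccc1F)Nc1cc2ncncc2cc1OCc1ccccc1F` gives 10000 nM, and compound 3 `O=C(Nc1cccc(Cl)c1)Nc1cc2ncncc2cc1OCc1ccccc1` gives 7400 nM. These two values cannot be told apart within the usual scatter. Compound 1 `O=C(Nc1cccc(F)c1)Nc1cc2ncncc2cc1OCc1cccc(Cl)c1` reaches only the assay limit, > 10000 nM, as the limit of > 10000 nM in this assay, at which 1 of the 3 values shown sits, records. Compound 4 `O=C(Nc1ccc(Cl)c(Cl)c1)Nc1cc2ncncc2cc1OCc1ccccc1F` has not yet been measured. It differs from compound 2 in a single place: 3,4-dichlorophenyl in place of 2-fluorophenyl on an amide-type nitrogen. For the measured compounds named here, no step of this kind appears among the measured compounds, so in this assay no change beyond the scatter is expected, in either direction. For compound 4 a value of 7000 nM is estimated, with a range from 3000 nM to 15000 nM. This estimate means an expected step of a 1.4-fold lower number from compound 2 to compound 4 (0.15 log units; within the scatter).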

Compound 4, half-maximal inhibitory concentration: 3900 nM
The estimate for compound 4 lay 1.8-fold (0.25 log units) above the measured number, within the range that was stated.
By their numbers in this assay, from the lowest: compounds 4, 3 and 2 (each within the scatter of the next, the first and the last beyond it).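

In this assay, the aryl group on an amide-type nitrogen proves able to move the number on its own: 3,4-dichlorophenyl in place of 2-fluorophenyl gives a 2.6-fold lower number from compound 2 to compound 4 (0.41 log units; beyond the scatter). This is the only step shown between measured compounds that differ in one place, and it is modest in size. Nothing shown gives a reason for this step. As far as these compounds go, every aryl group on that nitrogen here carries only halogens, so what an amine or a carboxylic acid on the ring would do stays open. One step also cannot separate the contributions of the two chlorines.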